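The compounds below may be only part of what the source reports. "The series", "measured", "known", "first", "only" and "open" are said of these compounds alone.

Measured so far:
- compound 1 `COc1cc(-c2nnc3n2NC(c2cccs2)C(C(=O)c2ccccc2)S3)cc(OC)c1OC`: in a functional assay on PC-3 cells (Homo sapiens) for cytotoxicity, read by MTT assay, with a stated time of 48 h (a lower number here means a stronger inhibitor, a higher number a weaker inhibitor), compound 1 gives 86300 nM
- compound 2 `COc1cc(C(=O)C2Sc3nnc(-c4cc(OC)c(OC)c(OC)c4)n3NC2c2cccs2)cc(OC)c1OC`: in this assay compound 2 gives > 100000 nM, a limit of the assay rather than a number

Compound 2 thus stands at the limit of > 100000 nM in this assay, at which 1 of the 2 values shown sits, and has no fixed place on the scale. Compound 3 `COc1cc(-c2nnc3n2NC(c2cccs2)C(C(=O)c2ccc(Cl)cc2)S3)cc(OC)c1OC` carries 4-chlorophenyl in place of 3,4,5-trimethoxyphenyl on a carbonyl carbon. For the measured compounds named here, the only measured step at that carbonyl carbon, an at least 1.1-fold higher number from compound 1 to compound 2 (0.06 log units; that floor lies within the scatter), lies within the scatter, so a further swap of the aryl group there is expected to move this assay by no more than the scatter. Compound 3 is expected near the value of compound 1, estimated at 80000 nM (range 30000 nM to 200000 nM). The expected step is an at least 1.2-fold lower number from compound 2 to compound 3 (0.09 log units; that floor lies within the scatter).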

Compound 3, half-maximal inhibitory concentration: 32500 nM
Beside the measured number, compound 3's estimate is 2.5-fold (0.39 log units) above it, and the stated range covers the measured number.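

In this assay the aryl group on the carbonyl carbon now makes a readable difference: 4-chlorophenyl gives an at least 3.0-fold lower number from compound 2 to compound 3 (0.48 log units; beyond the scatter) and chloro in place of hydrogen gives a 2.7-fold lower number from compound 1 to compound 3 (0.42 log units; beyond the scatter) on the same series. Unlike the earlier step at this carbonyl carbon, both steps lie beyond the scatter. The step from 3,4,5-trimethoxyphenyl is only a floor, since compound 2 gives a limit and not a number: the limit of > 100000 nM in this assay, at which 1 of the 3 values shown sits.

Open, as far as these compounds go, is whether the gain belongs to chlorine itself or would also follow from bromo, methyl or an amine on that phenyl ring. Also open, from the compounds shown here alone, is whether a carboxylic acid there would keep it.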